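The compounds below may be only part of what the source reports. "The series", "measured", "known", "first", "only" and "open" are said of these compounds alone.

In a functional assay on HeLa cells (Homo sapiens) for cytotoxicity, read by MTT assay, with a stated time of 72 h (a lower number here means a stronger inhibitor, a higher number a weaker inhibitor), the three measured compounds stand as follows:

- compound 1 `O=C(c1ccccc1)N(/N=N/c1ccc([N+](=O)[O-])cc1C(F)(F)F)c1ccc([N+](=O)[O-])cc1C(F)(F)F`: 600 nM
- compound 2 `O=C(c1ccccc1C(F)(F)F)N(/N=N/c1ccc([N+](=O)[O-])cc1C(F)(F)F)c1ccc([N+](=O)[O-])cc1C(F)(F)F`: 5350 nM
- compound 3 `O=C(c1cccc(F)c1)N(/N=N/c1ccc([N+](=O)[O-])cc1C(F)(F)F)c1ccc([N+](=O)[O-])cc1C(F)(F)F`: 880 nM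

Compound 3 holds the second highest of these three numbers. Its distance from compound 1 is small, a 1.5-fold higher number from compound 1 to compound 3 (0.17 log units; within the scatter), while the gap from compound 2 is larger, a 6.1-fold lower number from compound 2 to compound 3 (0.78 log units; beyond the scatter). Compound 4 `O=C(c1ccc(F)cc1)N(/N=N/c1ccc([N+](=O)[O-])cc1C(F)(F)F)c1ccc([N+](=O)[O-])cc1C(F)(F)F` differs from compound 3 by 4-fluorophenyl in place of 3-fluorophenyl on a carbonyl carbon. Among the measured compounds shown here, no measured step moves a fluorine from one carbon of the benzoyl ring to another; the only step that touches a fluoro substituent, a 1.5-fold higher number from compound 1 to compound 3 (0.17 log units; within the scatter), was small, whereas an 8.9-fold higher number from compound 1 to compound 2 (0.95 log units; beyond the scatter) came from a trifluoromethyl. Compound 4 is therefore expected to show no step beyond the scatter, a 1.0-fold higher number from compound 3 to compound 4 (0.01 log units; within the scatter). For compound 4 the estimate in this assay is 900 nM, between 400 nM and 2000 nM.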

Compound 4, half-maximal inhibitory concentration: 1000 nM
Beside the measured number, compound 4's estimate is 1.1-fold (0.05 log units) below it; the range from low to high includes it.
By their numbers in this assay, from the lowest: compounds 1, 3 and 4 (each within the scatter of the next); then compound 2.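

In this assay the step for moving the fluorine on the ring at the carbonyl carbon, a 1.1-fold higher number from compound 3 to compound 4 (0.06 log units; within the scatter), shows that 3-fluorophenyl and 4-fluorophenyl cannot be told apart here. The 4-fluorophenyl also stays close to plain phenyl, with a 1.7-fold higher number from compound 1 to compound 4 (0.22 log units; within the scatter), while the contrast with 2-(trifluoromethyl)phenyl, a 5.4-fold lower number from compound 2 to compound 4 (0.73 log units; beyond the scatter), remains clear. No measurement available accounts for these results. The compounds shown leave open whether the higher number of compound 2 belongs to the trifluoromethyl itself or to its place on the ring, and how a methoxy group or an amine there would read.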